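The source may report more compounds than this note shows. Statements on the series, on what has been measured and on what is new or still open speak of the compounds shown alone.

In a functional assay on HCT-116 cells (Homo sapiens) for cytotoxicity, read by scintillation counting and thymidine incorporation, with a stated time of 72 h (a higher number here means a weaker inhibitor, a lower number a stronger inhibitor), two compounds sharing one core have been measured so far. Compound 1 `COc1cc(OC)cc(C(=CC(N)=O)c2ccc(OC)c(OC)c2)c1` reads > 10000 nM, which is a limit of the assay and not a number. For the measured compounds named here, compound 2 `COc1cc(OC)cc(C(=CC#N)c2ccc(OC)c(OC)c2)c1` gives 18 nM, the only actual number available.

Compound 3 `COc1cc(OC)cc(C(=CCCN(C)C)c2ccc(OC)c(OC)c2)c1` keeps the shared core and changes one group of compound 2: 2-(dimethylamino)ethyl in place of cyano on a double-bonded chain carbon bound to a double-bonded chain carbon. Going by the values given here, the change falls at the same place as the single measured step, an at least 550-fold lower number from compound 1 to compound 2 (2.74 log units; beyond the scatter), which is large. Among the compounds with values here, that step is the only guide here. Read in reverse, it shows that a compound without the cyano group at this place, compound 1, can stand far weaker in this assay. One such replacement is thin evidence, and the group entering compound 3 is a different one, so the expectation is a large move toward a higher number, held with wide margins. The expected size is a 56-fold higher number from compound 2 to compound 3 (1.74 log units; beyond the scatter). For compound 3 the estimated value is 1000 nM, with an expected range from 50 nM to 10000 nM.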

Compound 3, half-maximal inhibitory concentration: > 10000 nM
Compound 3: no number, only a limit (the forecaster's own chance of this, stated with the estimate: 25%); middle value at least 10-fold (1.00 log units) from the limit.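

In this assay, 2-(dimethylamino)ethyl in place of cyano on a double-bonded chain carbon bound to a double-bonded chain carbon gives an at least 550-fold higher number from compound 2 to compound 3 (2.74 log units; beyond the scatter), so the large loss at this place is no longer tied to carbamoyl alone: two different groups entering for cyano have now both produced it, and among the three compounds shown only compound 2, which carries the cyano group, gives an actual number, with no compound going against this. The value of compound 3, > 10000 nM, is a limit of the assay and not a number. The step between compound 1 and compound 3 cannot be read, and carbamoyl and 2-(dimethylamino)ethyl cannot be ranked against each other, because both compounds stand at the same limit: the limit of > 10000 nM in this assay, at which 2 of the 3 values shown sit.

From the compounds shown here alone, how far beyond that limit compound 1 and compound 3 lie remains unknown, so the true size of either loss is open. For the compounds shown here, also open is whether the cyano group is the only group at this place that gives a measurable number, or whether a carboxylic acid, a methyl ester or a shorter amine chain would give one too.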